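Replacing an aminoethyl sulfanyl chain with an ethylcarbamoyl methyl chain

The compounds below may be only part of what the source reports. "The series", "measured", "known", "first", "only" and "open" are said of these compounds alone.

Measured so far:
- compound 1, `NCCSCCc1c[nH]c2ccc(F)cc12`: 4 nM
- compound 2, `NC(=O)CCc1c[nH]c2c(F)cccc12`: 271 nM

Both compounds were tested in an assay on isolated protein (urine) for inhibition of Myeloperoxidase (Homo sapiens), with a stated time of 5 min; on this read-out lower numbers stand for stronger inhibition and higher numbers for weaker inhibition. Compound 1 gives 4 nM, the lowest of the two numbers; compound 2 gives 271 nM, a gap that lies beyond the usual scatter. Among the measured compounds shown here, no single-point step between these two has been worked out, as they differ in more than one place, so their values are only read side by side.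

Compound 3, `CCNC(=O)CCCc1c[nH]c2ccc(F)cc12`, has not yet been measured. It differs from compound 1 in one place: (ethylcarbamoyl)methyl in place of (2-aminoethyl)sulfanyl on a saturated chain carbon, two bonds along the chain from an aromatic carbon. Nothing has been measured for this exact change, so any expectation rests on the two values at hand.

In this assay the step of a 38-fold higher number from compound 1 to compound 3 (1.57 log units; beyond the scatter) is expected to be a weakening beyond the scatter, since compound 2, which also carries a carbamoyl group on its chain, gives 271 nM. Compound 3 is therefore estimated at 150 nM, within a range of 20 nM to 1500 nM.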

Compound 3, half-maximal inhibitory concentration: 182 nM
Compound 3: middle estimate off by 1.2-fold (0.08 log units), on the low side, and the stated range covers the measured number.
By their numbers in this assay, from the lowest: compound 1; then compounds 3 and 2 (each within the scatter of the next).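

In this assay, putting (ethylcarbamoyl)methyl in place of (2-aminoethyl)sulfanyl on a saturated chain carbon, two bonds along the chain from an aromatic carbon, gives a 46-fold higher number from compound 1 to compound 3 (1.66 log units; beyond the scatter). Among the compounds shown here, this is the first direct comparison at this place: with the rest of compound 1 unchanged, altering this chain alone costs much of the inhibition, showing that the strong value of compound 1 depends on what this chain carries. Nothing measured here explains the loss.

The swap removes the sulfur and the amine together, leaving open which of them matters more for inhibition. An all-carbon chain ending in an amine, or a chain ending in a carboxylic acid, would help to separate these two parts of the change.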